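A few compounds are considered here, and "the series" means these few. Any claim that something is new, unique, unknown or untested is made for them only; others in the source may bear on it.

Measured so far in an assay on Sf9 cells for inhibition of histone deacetylase 11 (Homo sapiens), read by fluorescence, tested at 0.5 uM; on this read-out higher numbers stand for more inhibition at the one concentration tested (going by the name of the read-out) and lower numbers for less inhibition:
- compound 1 `O=C(NO)c1ccc(-c2cn([C@H]3C[C@@H](CO)N(CCCc4ccccc4)C3)nn2)cc1`; in this assay compound 1 gives < 10%, which is a limit of the assay and not a number.
- compound 2 `O=C(NO)c1ccc(-c2cn([C@H]3C[C@H](CO)N(CCCc4ccccc4)C3)nn2)cc1`; compound 2 gives 18%.
- compound 3 `O=C(/C=C/c1cn([C@H]2C[C@H](CO)N(CCCc3ccccc3)C2)nn1)NO`; compound 3 gives 16%.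

Compound 2 stands highest of the two numbers shown, with compound 3 nearest: a number 2 percentage points lower from compound 2 to compound 3 (within the scatter), so the two are not separated. Compound 1 shows only a limit; the step of a number at least 8 percentage points higher from compound 1 to compound 2 (that floor lies within the scatter) rests on the limit of < 10% in this assay, at which 1 of the 3 values shown sits, and the fact that compounds 1 and 2 differ only in the configuration as drawn and its floor lies within the scatter.

Compound 4 `O=C(NO)c1ccc(-c2cn([C@H]3C[C@H](C(=O)O)N(CCCc4ccccc4)C3)nn2)cc1` differs from compound 2 as follows: carboxy in place of hydroxymethyl on a saturated ring carbon. Among the measured compounds shown here, no measured step exchanges a hydroxymethyl for a carboxy, so neither measured step bears on this change directly; both measured steps are themselves within the scatter. With no indication either way, no step beyond the scatter is expected: a number 3 percentage points lower from compound 2 to compound 4 (within the scatter). Compound 4 is therefore estimated at 15%, within 5% to 30%, with some chance that only a limit is reported.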

Compound 4, a percentage reported as inhibition, at one concentration (the size of the read-out at that concentration, not a potency): < 10%
Compound 4 was reported as a limit (the forecaster's own chance of this, stated with the estimate: 25%); middle value at least 5 percentage points from the limit.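

Among the compounds shown here, this is the first change at the saturated ring carbon next to the ring nitrogen, and in this assay the carboxy in place of hydroxymethyl gives a number at least 8 percentage points lower from compound 2 to compound 4 (that floor lies within the scatter). Compound 4 is reported as < 10%, which is a limit of the assay and not a number. The carboxy compound therefore shows no measurable gain over the hydroxymethyl compound, but the size of any loss cannot be read, and the step can be taken only as far as its floor allows: the limit of < 10% in this assay, at which 2 of the 4 values shown sit.

The compounds shown leave open how an aminomethyl, a methyl ester or a carboxamide at this ring carbon would read in this assay. They also leave open how carboxy would read with the configuration drawn in compound 1 or with the 2-(hydroxycarbamoyl)ethenyl group of compound 3.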